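Aryl swap and liver clearance across two cores

The compounds below may be only part of what the source reports. "The series", "measured", "known", "first", "only" and "open" are said of these compounds alone.

Compound 1 `O=S(=O)(c1cc(Cl)cc(Cl)c1)c1cnc2cc(F)ccc2c1-c1ccc(F)cc1` and compound 2 `COc1cccc(-c2c(S(=O)(=O)c3cc(Cl)cc(Cl)c3)cnc3cc(F)ccc23)c1` share one core; compound 3 `O=S(=O)(c1cccc(F)c1)c1cnc2c(F)cccc2c1-c1ccc(F)cc1` and compound 4 `COc1cccc(-c2c(S(=O)(=O)c3cccc(F)c3)cnc3c(F)cccc23)c1` share another, and the difference between the two cores is not broken down here. In an ADME assay on microsomes from liver (Homo sapiens) for metabolic stability, tested at 2.5 uM (a lower number here means slower removal, a higher number faster removal of the compound), compound 1 gives 0.18 mL/min and compound 2 gives 1.51 mL/min; the change 3-methoxyphenyl in place of 4-fluorophenyl on an aromatic carbon made an 8.4-fold higher number from compound 1 to compound 2 (0.92 log units; beyond the scatter). In this assay compound 3 gives 0.19 mL/min, which sits within the scatter of compound 1 and well apart from compound 2. Compound 4 carries the same change on its own core, (3-methoxyphenyl in place of 4-fluorophenyl on an aromatic carbon), and the two places read the same word for word. Since this change has been measured only once, the step is expected to be of similar size, a 7.9-fold higher number from compound 3 to compound 4 (0.90 log units; beyond the scatter), because the earlier instance gave an 8.4-fold higher number from compound 1 to compound 2 (0.92 log units; beyond the scatter). Compound 4 is therefore expected to give 1.5 mL/min, with a likely range from 0.6 mL/min to 3.5 mL/min.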

Compound 4, intrinsic clearance in a liver preparation (reported as CLH), per the amount of preparation that the assay uses: 2.6 mL/min
The estimate for compound 4 lay 1.7-fold (0.24 log units) below the measured number, and the stated range covers the measured number.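

In this assay, 3-methoxyphenyl in place of 4-fluorophenyl on an aromatic carbon gave a 14-fold higher number from compound 3 to compound 4 (1.14 log units; beyond the scatter), so the change raises the number on both cores. The two instances agree in direction and do not differ in size beyond the scatter: the same change on two cores in this assay, an 8.4-fold higher number (0.92 log units; beyond the scatter) from compound 1 to compound 2 and a 14-fold higher number (1.14 log units; beyond the scatter) from compound 3 to compound 4, 1.6-fold (0.21 log units) apart, within the scatter of two such steps. Within the data shown here, this supports carrying the change between these two cores, but it rests on only two pairs and does not show which feature of the 3-methoxyphenyl group sets the step, or how the change reads on any other core.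

On these data alone, whether an unsubstituted phenyl, or a phenyl carrying a hydroxyl or an amine, would give a similar step stays open. Also open, as far as these compounds go, is whether the step would survive with a pyridine in place of the 3-methoxyphenyl ring.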